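Removing the tert-butyl group from a nucleoside triazole

The source may report more compounds than this note shows. Statements on the series, on what has been measured and on what is new or still open speak of the compounds shown alone.

Three nucleoside analogues have been tested in a functional assay on NCI-H23 cells (Homo sapiens) for cytotoxicity, read by sulforhodamine B assay, tested at 10 uM; on this read-out lower numbers stand for less inhibition and higher numbers for more inhibition at the one concentration tested (going by the name of the read-out). Compound 1, `CC(C)(C)c1ccc(-c2cc(-c3cn([C@H]4C[C@H](O)[C@@H](CO)O4)c(=O)[nH]c3=O)on2)cc1`, gives 98.9% in this assay. Compound 2, `CC(=O)OC[C@H]1O[C@@H](n2cc(-c3cc(C)no3)c(=O)[nH]c2=O)C[C@@H]1OC(C)=O`, gives 101%. Compound 3, `CC(C)(C)c1ccc(Cn2cc(-c3cn([C@H]4C[C@H](O)[C@@H](CO)O4)c(=O)[nH]c3=O)nn2)cc1`, gives 95%. The three numbers lie within the usual scatter of one another, so compound 3 cannot be set apart from compound 1 or compound 2 on these readings: the inhibition in this assay is level across all three at the single concentration tested.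

The next compound, compound 4, is `O=c1[nH]c(=O)n([C@H]2C[C@H](O)[C@@H](CO)O2)cc1-c1cn(Cc2ccccc2)nn1`. It differs from compound 3 in one place: hydrogen in place of tert-butyl on an aromatic carbon. A tert-butyl group leaves a six-membered aromatic ring of carbon only, and a hydrogen atom enters where it stood.

Among the compounds with values here, no step between two measured compounds matches this change, so the expectation rests on how close the three measured numbers already lie. Because compound 3 sits at 95%, there is little room upward, and a drop beyond the scatter would need the tert-butyl group to carry much of the effect, which nothing here shows. The step expected from compound 3 to compound 4, a number 5 percentage points lower from compound 3 to compound 4 (within the scatter), is small and not beyond the scatter. Compound 4 is therefore expected to give about 90%, within a range from 65% to 102%.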

Compound 4, a percentage reported as inhibition, at one concentration (the size of the read-out at that concentration, not a potency): 97.5%
Compound 4: the middle estimate sits 7.5 percentage points below what was measured; the measured number falls inside the stated range.
By their numbers in this assay, from the lowest: compounds 3, 4, 1 and 2 (each within the scatter of the next).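

In this assay, going from 4-(tert-butyl)phenyl to phenyl, with a hydrogen atom in place of the tert-butyl group, gives a number 2.5 percentage points higher from compound 3 to compound 4 (within the scatter). Within the data shown here, this is the first pair here that differs in one place only, and it shows that, at the single concentration tested, the reading does not depend on the tert-butyl group at this position on the six-membered aromatic ring of carbon only. No measurement at hand explains why the reading stays level across this change.

The compounds shown leave open whether other groups at this position, such as an amine, a carboxylic acid or a longer alkyl chain, would also leave the reading level. Since a reading at one concentration is not a potency, they also leave open whether compound 3 and compound 4 would separate at lower concentrations, where a real difference between them could show.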